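Working notes: aryl ether variation in a thiazolidinedione-linked series

The source may report more compounds than this note shows. Statements on the series, on what has been measured and on what is new or still open speak of the compounds shown alone.

The series is read in a functional assay on MCF7 cells (Homo sapiens), tested at 5 uM; on this read-out lower numbers stand for a stronger effect and higher numbers for a weaker effect at the one concentration tested. Compound 1 `C=CCOc1c(C)c(C)c2c(c1C)CCC(C)(COc1ccc(/C=C3\SC(=O)NC3=O)cc1OC)O2` gives 5% in this assay. Compound 2 `C=CCOc1c(C)c(C)c2c(c1C)CCC(C)(COc1cccc(/C=C3\SC(=O)NC3=O)c1)O2` gives 92%. Compound 3 `Cc1c(C)c2c(c(C)c1OC(=O)CCC(=O)O)CCC(C)(COc1ccc(/C=C3\SC(=O)NC3=O)cc1)O2` gives 98%, the highest number of the three; its gap to compound 2 lies within the scatter, while its gap to compound 1 lies well beyond it.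

The step under consideration goes from compound 3 to compound 4 `CC(C)=CCOc1c(C)c(C)c2c(c1C)CCC(C)(COc1ccc(/C=C3\SC(=O)NC3=O)cc1)O2`. The change is 3-methylbut-2-en-1-yl in place of (2-carboxyethyl)carbonyl on an oxygen on an aromatic ring. Among the compounds with values here, no step between two measured compounds isolates this change, so its size can only be guessed from what the three numbers show. Compound 1, which also carries an ether on that aromatic oxygen and additionally a methoxy group, gives a strong effect, whereas compound 2, with an ether on that oxygen but a different arrangement on the other ring, gives a weak one. Compound 4 shares the ether feature with both, so a drop from compound 3 is expected but its size is uncertain. The expected step from compound 3 to compound 4 is a number 43 percentage points lower from compound 3 to compound 4 (beyond the scatter), a drop beyond the scatter but with a wide range. Compound 4 is thus estimated at 55%, between 10% and 100%.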

Compound 4, a percentage reported as activity, at one concentration (the size of the read-out at that concentration, not a potency): 21%
Compound 4: the middle estimate sits 34 percentage points above what was measured, and the stated range covers the measured number.
By their numbers in this assay, from the lowest: compound 1; then compound 4; then compounds 2 and 3 (each within the scatter of the next).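

In this assay, within the data shown here, the exchange of (2-carboxyethyl)carbonyl for 3-methylbut-2-en-1-yl on an oxygen on an aromatic ring gives a number 77 percentage points lower from compound 3 to compound 4 (beyond the scatter) and is the first step that isolates a single place. With the rest of the molecule held the same, the group on this oxygen alone moves the read-out well beyond the scatter, so this position cannot be treated as indifferent to substitution. Nothing at hand gives a reason for the size of this step.

The step exchanges several features together: the entering group has no carbonyl, no carboxylic acid end and a different chain, and the two compounds alone cannot assign the change to any one of these. A 3-methylbutyl group on the same oxygen would show what the chain double bond contributes, while a carboxymethyl group attached through an ether would show whether the carboxylic acid end matters once the ester carbonyl is gone.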